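A few compounds are considered here, and "the series" means these few. Any claim that something is new, unique, unknown or untested is made for them only; others in the source may bear on it.

Measured so far:
- compound 1 `Oc1ccc(CN(Cc2cccc(C(F)(F)F)c2)Cc2ccc(O)c3ncccc23)c2cccnc12`: 57 nM
- compound 2 `Oc1ccc(CN(Cc2cccc(I)c2)Cc2ccc(O)c3ncccc23)c2cccnc12`: 446 nM

In a functional assay on T98G cells (Homo sapiens) for cytotoxicity, read by MTT assay (on this read-out higher numbers stand for weaker inhibition and lower numbers for stronger inhibition), compound 2 gives 446 nM, the higher of the two numbers and thus the weaker inhibition. Compound 3 `O=C(O)C1CCC(CN(Cc2ccc(O)c3ncccc23)Cc2ccc(O)c3ncccc23)CC1` differs from it by 4-carboxycyclohexyl in place of 3-iodophenyl on a saturated chain carbon bound to an amine nitrogen, with 4-carboxycyclohexyl in place of 3-iodophenyl on a saturated chain carbon bound to an amine nitrogen.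

Among the compounds with values here, only one measured step bears on this change: a 7.8-fold higher number from compound 1 to compound 2 (0.89 log units; beyond the scatter). That step alters a substituent on the aromatic group but keeps the group itself, so it is only indirect evidence. Within the data shown here, no measured compound has a non-aromatic ring or a carboxy group at this place. Even a substituent swap moved the number beyond the scatter, so replacing the whole group is expected to give a step at least as large, probably towards weaker inhibition, though the direction is uncertain.

The estimated change is a 4.5-fold higher number from compound 2 to compound 3 (0.65 log units; beyond the scatter). For compound 3 the expected value is 2000 nM, with an estimated range of 350 nM to 10000 nM.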

Compound 3, half-maximal inhibitory concentration: 9760 nM
Compound 3: middle estimate off by 4.9-fold (0.69 log units), on the low side; measured number inside the range.
By their numbers in this assay, from the lowest: compound 1; then compound 2; then compound 3.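

In this assay, exchanging the whole group on a saturated chain carbon bound to an amine nitrogen, 3-iodophenyl for 4-carboxycyclohexyl, gives a 22-fold higher number from compound 2 to compound 3 (1.34 log units; beyond the scatter) and so a larger step than the substituent swap on the aromatic group, a 7.8-fold higher number from compound 1 to compound 2 (0.89 log units; beyond the scatter) in size. Starting from 3-(trifluoromethyl)phenyl, the exchange gives a 170-fold higher number from compound 1 to compound 3 (2.23 log units; beyond the scatter) and settles the direction for this change: both aromatic groups shown give lower numbers than 4-carboxycyclohexyl. Nothing on hand accounts for the size of these steps.

The non-aromatic ring and the carboxylic acid enter together in compound 3, so their separate contributions remain unresolved. An unsubstituted cyclohexyl or a phenyl ring carrying a carboxylic acid at this place would separate the two.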